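A Further Acetylazetidine Amide Awaits Its Measurement

The compounds below may be only part of what the source reports. "The series", "measured", "known", "first", "only" and "open" are said of these compounds alone.

In a physicochemical assay for solubility, read by spectrophotometry, measured as kinetic solubility, at pH 8, tested at 500 uM (a lower number here means a less soluble compound, a higher number a more soluble compound), compound 1 `CN1CC(NC(=O)c2ccncc2Nc2cc(-c3ccc4ccn(C)c4c3)c3nccnc3c2)C1` gives 170 ug/mL and compound 2 `CC(=O)N1CC(NC(=O)c2ccncc2Nc2cc(-c3ccc4ccn(C)c4c3)c3nccnc3c2)C1` gives 244 ug/mL, so compound 2 stands within the scatter of compound 1. Compound 3 `CC(=O)N1CC(CNC(=O)c2ccncc2Nc2cc(-c3ccc4ccn(C)c4c3)c3nccnc3c2)C1` brings ((1-acetylazetidin-3-yl)methyl in place of 1-acetylazetidin-3-yl on an amide-type nitrogen). Among the compounds with values here, the only measured step, a 1.4-fold higher number from compound 1 to compound 2 (0.16 log units; within the scatter), swaps methyl for acetyl on an amine nitrogen in a ring, stays within the scatter, and changes a different place, so it offers only weak guidance. No step beyond the scatter is therefore expected, and the estimated step is a 1.2-fold lower number from compound 2 to compound 3 (0.07 log units; within the scatter). Compound 3 is expected at 210 ug/mL, with an estimated range of 110 ug/mL to 300 ug/mL.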

Compound 3, solubility: 252 ug/mL
Beside the measured number, compound 3's estimate is 1.2-fold (0.08 log units) below it; the measured number falls inside the stated range.
By their numbers in this assay, from the lowest: compounds 1, 2 and 3 (each within the scatter of the next).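

At the amide-type nitrogen, (1-acetylazetidin-3-yl)methyl in place of 1-acetylazetidin-3-yl gives a 1.0-fold higher number from compound 2 to compound 3 (0.01 log units; within the scatter) in this assay. Put in place of 1-methylazetidin-3-yl at the same nitrogen, the group gives a 1.5-fold higher number from compound 1 to compound 3 (0.17 log units; within the scatter). Within the data shown here, neither change at this place therefore leaves the scatter, and the earlier compounds held no change of this kind at this nitrogen. Going by these compounds, whether a longer chain or a carboxylic acid on that nitrogen would step beyond the scatter stays open. Nothing measured here offers an explanation for these steps.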